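Swapping a Bromophenyl for an Iodoethenyl Group

This account rests on a few compounds, and the source may have more. Where it says the series, first, only, none or still open, it means among the compounds named here.

Measured compounds:
compound 1, `OC1CN(Cc2cccc(Br)c2)CCC1N1CCN(c2ccccc2)CC1`: 66 nM
compound 2, `C=CCN1CCC(N2CCN(c3ccccc3)CC2)C(O)C1`: a limit, > 100 nM

Going by the values given here, in an assay on PC-12 cells for displacement of a labelled ligand from vesicular acetylcholine transporter (Homo sapiens) (a lower number here means a stronger inhibitor, a higher number a weaker inhibitor), compound 1 gives 66 nM and is the only compound with a numerical value here. Compound 2 reaches only a limit in this assay, > 100 nM; this is the limit of > 100 nM in this assay, at which 1 of the 2 values shown sits. Among the compounds with values here, the single measured step, an at least 1.5-fold higher number from compound 1 to compound 2 (0.18 log units; that floor lies within the scatter), puts vinyl in place of 3-bromophenyl on a saturated chain carbon bound to an amine nitrogen in a ring and points toward a higher number, though its floor lies within the scatter.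

Compound 3, `OC1CN(C/C=C/I)CCC1N1CCN(c2ccccc2)CC1`, makes a change of the same kind at the same place: 2-iodoethenyl in place of 3-bromophenyl on a saturated chain carbon bound to an amine nitrogen in a ring. Cut one bond further out, it reads as 3-bromobenzyl to 3-iodoprop-2-en-1-yl. Within the data shown here, the step to compound 2 is the only guide, so compound 3 is expected to sit at a higher number, with the expected step of a 3.0-fold higher number from compound 1 to compound 3 (0.48 log units; beyond the scatter). Compound 3 is estimated at 200 nM, with a range from 60 nM to 800 nM.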

Compound 3, half-maximal inhibitory concentration: > 100 nM
Compound 3 was reported as a limit; the forecaster's own chance of this, stated with the estimate: 50%; the middle value is on the limit's open side.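

In this assay, the value of compound 3 is a limit, not a number. Replacing 3-bromophenyl with 2-iodoethenyl gives an at least 1.5-fold higher number from compound 1 to compound 3 (0.18 log units; that floor lies within the scatter), so a second group in this place, on a saturated chain carbon bound to an amine nitrogen in a ring, yields no number, though this floor does not establish a loss beyond the scatter. Compound 2 and compound 3 now stand at the same limit, and the step between them cannot be read: the limit of > 100 nM in this assay, at which 2 of the 3 values shown sit.

Going by these compounds, it remains open how far past this limit compound 2 and compound 3 lie, and so whether either truly differs from compound 1 beyond the scatter. On these data alone, it is also open whether the ring or the bromine of the 3-bromophenyl group matters, which a plain phenyl or a 3-iodophenyl group in the same place could address.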